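Series notes: from compound 3 to compound 4

The compounds below may be only part of what the source reports. "The series", "measured", "known", "first", "only" and "open" are said of these compounds alone.

Measured so far in a functional assay on A549 cells (Homo sapiens) for cytotoxicity, read by MTT assay, with a stated time of 72 h; on this read-out higher numbers stand for weaker inhibition and lower numbers for stronger inhibition:
compound 1 `CN(C)CCn1cnnc1-c1cc(Oc2ccc(NC(=O)N/N=C/c3ccc(F)cc3)cc2F)ccn1` gives 1790 nM
compound 2 `CN(C)CCn1cnnc1-c1cc(Oc2ccc(NC(=O)N/N=C/c3ccc(F)cc3F)cc2F)ccn1` gives 1870 nM
compound 3 `CN(C)CCn1cnnc1-c1cc(Oc2ccc(NC(=O)N/N=C/c3ccc(O)c(O)c3)cc2F)ccn1` gives > 100000 nM

Compound 1 and compound 2 sit close together in this assay: a 1.0-fold higher number from compound 1 to compound 2 (0.02 log units; within the scatter). The value of compound 3 is a limit of this assay and not a number, (the limit of > 100000 nM in this assay, at which 1 of the 3 values shown sits). The steps that lead to it are large: an at least 55-fold higher number from compound 1 to compound 3 (1.74 log units; beyond the scatter) and an at least 53-fold higher number from compound 2 to compound 3 (1.72 log units; beyond the scatter). On the numbers shown, compound 3 therefore stands at the weak end of the three, beyond the scatter from both others.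

Compound 4 `COc1ccc(/C=N/NC(=O)Nc2ccc(Oc3ccnc(-c4nncn4CCN(C)C)c3)c(F)c2)cc1O` differs from compound 3 in one place: methyl in place of hydrogen on an oxygen on an aromatic ring. Within the data shown here, no measured step exchanges a hydroxy for a methoxy, so the only steps that bear on this change are the two large losses on going from the fluorinated phenyl rings of compound 1 and compound 2 to the dihydroxyphenyl of compound 3. Compound 4 still carries one hydroxy on that ring. A move back toward the values of compound 1 and compound 2 is not expected from these steps; in this assay a small step, an at least 1.6-fold lower number from compound 3 to compound 4 (0.22 log units; that floor lies within the scatter), is expected at most. The estimate for compound 4 in this assay is 60000 nM, between 8000 nM and 300000 nM, with a real chance that again only a limit is reported.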

Compound 4, half-maximal inhibitory concentration: > 100000 nM
Compound 4 ended at the assay's limit; the forecaster's own chance of this, stated with the estimate: 50%; middle value at least 1.6-fold (0.22 log units) away from the limit.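

The loss against the fluorinated phenyl rings does not depend on two free hydroxy groups, since it stands with 3-hydroxy-4-methoxyphenyl on the carbon with a double bond to nitrogen (an at least 55-fold higher number from compound 1 to compound 4 (1.74 log units; beyond the scatter); an at least 53-fold higher number from compound 2 to compound 4 (1.72 log units; beyond the scatter)). The step between compound 3 and compound 4 cannot be read, so methyl in place of hydrogen on this oxygen shows no measurable recovery, though a small change stays hidden. In this assay compound 4 gives > 100000 nM, which is a limit and not a number, and this limit now recurs in the series: the limit of > 100000 nM in this assay, at which 2 of the 4 values shown sit.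

The compounds shown leave open whether a methoxyphenyl ring carrying no hydroxy, or an amine or a carboxylic acid on that ring, would come back toward compound 1 at 1790 nM, which would show whether the remaining hydroxy goes with the loss. They also give no number for compound 3 or compound 4 that would place these two in order.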